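Removing a methoxy group and widening the ring

The source may report more compounds than this note shows. Statements on the series, on what has been measured and on what is new or still open speak of the compounds shown alone.

Three compounds share one core, and only their outer rings differ. Compound 1 `COc1ccc(C2CC(c3ccccc3)=NN2C2=NC(=O)/C(=C3\C(=O)Nc4ccccc43)S2)cc1` gives 1810 nM in a functional assay on cells (Cancer cell lines, Homo sapiens) for cytotoxicity, read by sulforhodamine B assay, with a stated time of 48 h; a lower number here means a stronger inhibitor of growth, a higher number a weaker inhibitor of growth. Compound 2 `COc1ccc(C2=NN(C3=NC(=O)/C(=C4\C(=O)Nc5ccccc54)S3)C(c3ccc(OC)cc3)C2)cc1` gives 100000 nM, the highest of the three numbers shown, so it is the weakest growth inhibitor here. Compound 3 `COc1ccc(C2=NN(C3=NC(=O)/C(=C4\C(=O)Nc5ccc(Br)cc54)S3)C(c3ccc(OC)cc3)C2)cc1` gives 200 nM. The change from compound 1 to compound 2, a methoxy in place of hydrogen on an aromatic carbon, brought a 55-fold higher number from compound 1 to compound 2 (1.74 log units; beyond the scatter), a large rise; the change from compound 2 to compound 3, a bromo in place of hydrogen on an aromatic carbon, brought a 500-fold lower number from compound 2 to compound 3 (2.70 log units; beyond the scatter), a large fall.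

Compound 4 `COc1ccc(C2CC(c3ccc4ccccc4c3)=NN2C2=NC(=O)/C(=C3\C(=O)Nc4ccccc43)S2)cc1` is not yet measured. It differs from compound 2 by naphthalen-2-yl in place of 4-methoxyphenyl on a carbon with a double bond to nitrogen. This step undoes the methoxy whose arrival made compound 2 so much weaker than compound 1, and it enlarges the ring. The step from compound 1 to compound 2 is therefore the one that bears on it; the bromo step concerns another ring and is less relevant. For compound 4 a large fall from compound 2 is expected, of about a 50-fold lower number from compound 2 to compound 4 (1.70 log units; beyond the scatter), landing near compound 1. Compound 4 is thus estimated at 2000 nM, within a range from 400 nM to 20000 nM.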

Compound 4, concentration for 50% growth inhibition: 1680 nM
Compound 4: the middle estimate sits 1.2-fold (0.08 log units) above what was measured; measured number inside the range.
By their numbers in this assay, from the lowest: compound 3; then compounds 4 and 1 (each within the scatter of the next); then compound 2.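

On the carbon with a double bond to nitrogen, naphthalen-2-yl in place of 4-methoxyphenyl gives a 60-fold lower number from compound 2 to compound 4 (1.77 log units; beyond the scatter) in this assay, so the poor result of compound 2 does not follow from size alone: the group that enters has more heavy atoms than the one that leaves. Phenyl and naphthalen-2-yl cannot be told apart at this position, with a 1.1-fold lower number from compound 1 to compound 4 (0.03 log units; within the scatter), which makes 4-methoxyphenyl the exception among the three groups shown. Nothing measured here explains why this group stands apart.

The compounds shown leave open how this position responds to a smaller or different group, such as an amine, a carboxylic acid or a longer carbon chain. They also leave open whether the bromo that lowered the number for compound 2 would do the same for compound 4.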